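Salicylhydrazone series: bromo added at the aldehyde-derived ring

The compounds below may be only part of what the source reports. "The series", "measured", "known", "first", "only" and "open" are said of these compounds alone.

Measured so far:
compound 1 `Cc1ccc(C(=O)N/N=C/c2ccccc2O)c(O)c1` — 1020 nM
compound 2 `Cc1ccc(C(=O)N/N=C/c2ccccc2[N+](=O)[O-])c(O)c1` — > 100000 nM

Going by the values given here, in a functional assay (Mus musculus, strain BALB/C) for inhibition, read by MTT assay, with stated times of 24 h and 72 h (on this read-out lower numbers stand for stronger inhibition and higher numbers for weaker inhibition), compound 1 gives 1020 nM, the only number in the set. Compound 2 `Cc1ccc(C(=O)N/N=C/c2ccccc2[N+](=O)[O-])c(O)c1` reaches only a limit of this assay, > 100000 nM, and no number. Among the compounds with values here, the single measured step is an at least 98-fold higher number from compound 1 to compound 2 (1.99 log units; beyond the scatter), the nitro-for-hydroxy swap, with compound 2 sitting at the limit of > 100000 nM in this assay, at which 1 of the 2 values shown sits. Compound 1 therefore stands as the sole measured point, and the hydroxy on the aldehyde-derived ring is associated with the measurable number.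

Compound 3 `Cc1ccc(C(=O)N/N=C/c2cc(Br)ccc2O)c(O)c1` keeps that hydroxy and differs from compound 1 by bromo in place of hydrogen on an aromatic carbon. Within the data shown here, no measured step concerns a bromo, and the swap from compound 1 to compound 2 changes a different group, so it bears on compound 3 only in that compound 3 retains the hydroxy. No evidence here indicates how a bromo at this position shifts the number. The expected outcome is a step within the usual scatter, expressed as a 1.4-fold lower number from compound 1 to compound 3 (0.13 log units; within the scatter). Compound 3 is therefore estimated at 750 nM in this assay, with a range of 250 nM to 2500 nM.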

Compound 3, half-maximal inhibitory concentration: 1090 nM
Compound 3: middle estimate off by 1.5-fold (0.16 log units), on the low side, and the stated range covers the measured number.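

In this assay, the step for bromo in place of hydrogen on an aromatic carbon, para to a hydroxy group, is a 1.1-fold higher number from compound 1 to compound 3 (0.03 log units; within the scatter). The earlier compounds shown here showed only what happens when the hydroxy group itself is exchanged; this pair shows that the same ring can also carry a bromo at this place, meta to a large group, with the hydroxy kept and the two numbers within the scatter of each other. The data on hand offer no measured property that would account for this result.

Going by these compounds, one substituent at one place cannot show whether this position accepts groups in general, so it remains open whether a fluoro, a methoxy, an amine or a carboxylic acid here would read like the bromo. On these data alone, it is also open whether the bromo would leave the number where it stands without the hydroxy group, and whether an amine in place of that hydroxy would keep a measurable number as the hydroxy does in compound 1 and compound 3.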